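The compounds below may be only part of what the source reports. "The series", "measured", "known", "first", "only" and "open" are said of these compounds alone.

Measured compounds in a functional assay on A-375 cells (Homo sapiens) for cytotoxicity, read by MTT assay, with a stated time of 72 h; on this read-out higher numbers stand for weaker inhibition and lower numbers for stronger inhibition:
- compound 1, `CN1CCN(CCCCCn2c3c(c4ccccc42)C(=O)c2c[n+]([O-])c4ccccc4c2C3=O)CC1`: 1710 nM
- compound 2, `O=C1c2c[n+]([O-])c3ccccc3c2C(=O)c2c1c1ccccc1n2Cc1cn([C@H]2C[C@H](O)[C@@H](CO)O2)nn1`: 390 nM
- compound 3, `O=C1c2c[n+]([O-])c3ccccc3c2C(=O)c2c1c1ccccc1n2Cc1cn([C@H]2O[C@H](CO)[C@@H](O)[C@H]2O)nn1`: 340 nM

Compound 1 gives the highest number of the three in this assay; compound 2 and compound 3 both lie below it, and both gaps stand beyond the scatter. For the measured compounds named here, compound 2 and compound 3 sit within the scatter of each other, as the one single-point step in the set, a 1.1-fold lower number from compound 2 to compound 3 (0.06 log units; within the scatter), shows; that step concerns a change on an aromatic nitrogen and has no bearing on the chain carried by compound 1.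

Compound 4, `CCCN1CCN(CCCCn2c3c(c4ccccc42)C(=O)c2c[n+]([O-])c4ccccc4c2C3=O)CC1`, differs from compound 1 by 4-propylpiperazin-1-yl in place of (4-methylpiperazin-1-yl)methyl on a saturated chain carbon, four bonds along the chain from an aromatic nitrogen. Going by the values given here, no measured pair in the set varies either the length of this chain or the substituent on the piperazine nitrogen, so nothing in the numbers points to a shift in either direction. The expectation for compound 4 in this assay is therefore a step of a 1.1-fold lower number from compound 1 to compound 4 (0.03 log units; within the scatter), which is within the scatter. Compound 4 is estimated at 1600 nM, with a range from 600 nM to 4200 nM.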

Compound 4, half-maximal inhibitory concentration: 870 nM
Compound 4: middle estimate off by 1.8-fold (0.26 log units), on the high side, within the range that was stated.
By their numbers in this assay, from the lowest: compounds 3 and 2 (each within the scatter of the next); then compounds 4 and 1 (each within the scatter of the next).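

In this assay, for the compounds shown here, 4-propylpiperazin-1-yl in place of (4-methylpiperazin-1-yl)methyl on a saturated chain carbon, four bonds along the chain from an aromatic nitrogen, gives a 2.0-fold lower number from compound 1 to compound 4 (0.29 log units; within the scatter), the first step in the set to read this position. The position therefore accepts this change with no shift that stands clear of the scatter, although one step on one pair says little about the position as a whole. Read one bond further out, the difference is 4-(4-methylpiperazin-1-yl)butyl to 3-(4-propylpiperazin-1-yl)propyl, so the chain and the substituent on the piperazine nitrogen change together, and no information on any property of these groups accompanies the result.

The compounds shown leave open how the chain length and the piperazine substituent each read alone, since a single step cannot divide its size between them. Also open, going by these compounds, is how a morpholine or a primary amine at the end of the chain, or a longer chain carrying the same piperazine, would stand in this assay.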